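A few compounds are considered here, and "the series" means these few. Any claim that something is new, unique, unknown or untested is made for them only; others in the source may bear on it.

Measured so far in a functional assay on cells (Homo sapiens) for antiproliferative activity, read by MTT assay, with a stated time of 48 h; a higher number here means a weaker inhibitor, a lower number a stronger inhibitor:

- Compound 1 `CCN(CC)CCn1c(N)c(-c2nc3ccccc3[nH]2)c2nc(C#N)c(C#N)nc21`: 25400 nM
- Compound 2 `CN(C)CCn1c(N)c(-c2nc3cc(Cl)ccc3[nH]2)c2nc(C#N)c(C#N)nc21`: > 50000 nM (a limit of the assay, not a number)

Going by the values given here, only two compounds have been tested, so the evidence is thin. Compound 2 has no exact value: its result in this assay is the limit > 50000 nM. the limit of > 50000 nM in this assay, at which 1 of the 2 values shown sits, is the only such limit so far, and the other result, from compound 1, is a true number.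

The next compound, compound 3 `CCN(CC)CCn1c(N)c(-c2nc3cc(Cl)ccc3[nH]2)c2nc(C#N)c(C#N)nc21`, keeps the structure of compound 2 except for one change: diethylamino in place of dimethylamino on a saturated chain carbon, two bonds along the chain from an aromatic nitrogen. diethylamino in place of dimethylamino on a saturated chain carbon, two bonds along the chain from an aromatic nitrogen

Among the compounds with values here, no measured pair shows this change alone, so any expectation is tentative. Within the data shown here, compound 3 shares its diethylamino group with compound 1, which gives 25400 nM, and this is the only guide to a likely number. In this assay a modest step towards a stronger inhibitor is expected, estimated as an at least 1.6-fold lower number from compound 2 to compound 3 (0.22 log units; that floor lies within the scatter). A result that again reaches the limit would be no surprise. For compound 3 the expected value is 30000 nM, with an estimated range from 12000 nM to 50000 nM.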

Compound 3, half-maximal inhibitory concentration: > 50000 nM
Compound 3 ended at the assay's limit; the forecaster's own chance of this, stated with the estimate: 30%; middle value at least 1.6-fold (0.22 log units) away from the limit.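

In this assay, the new information comes from the pair that shares the diethylamino group, where chloro stands in place of hydrogen on an aromatic carbon: the result is an at least 1.9-fold higher number from compound 1 to compound 3 (0.29 log units; that floor lies within the scatter). Going by these compounds alone, that floor alone does not establish a real loss, although compound 1 is so far the only compound without chloro and the only one with a true number, while both compounds with chloro end at a limit of the assay. The effect of diethylamino in place of dimethylamino on a saturated chain carbon, two bonds along the chain from an aromatic nitrogen, still cannot be read, because compound 2 and compound 3 share the same limit and neither gives a true number: the limit of > 50000 nM in this assay, at which 2 of the 3 values shown sit.

The compounds shown leave open how far the chloro compounds really lie from compound 1, and what dimethylamino does on the core without chloro. They also leave open whether fluoro or methoxy in place of chloro, or a morpholine in place of diethylamino, would give a true number in this assay.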